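A few compounds are considered here, and "the series" means these few. Any claim that something is new, unique, unknown or untested is made for them only; others in the source may bear on it.

Measured compounds:
Compound 1, `COc1ccc([C@@H]2C/C(=N\O)c3c(O)cc(OCc4cn(CC5CC5)nn4)cc3O2)cc1O`, 6320 nM.
Compound 2, `CCn1cc(COc2cc(O)c3c(c2)O[C@H](c2ccc(OC)c(O)c2)CC3=O)nn1`, 15000 nM.
Compound 3, `COc1ccc([C@@H]2C/C(=N\O)c3c(O)cc(OCc4cn(C5CCCC5)nn4)cc3O2)cc1O`, 6880 nM.

In a functional assay on RAW264.7 cells (Mus musculus) for inhibition, read by Griess assay, with stated times of 2 h and 24 h (on this read-out lower numbers stand for stronger inhibition and higher numbers for weaker inhibition), compound 2 gives the highest of the three numbers, its nearest neighbour being compound 3 and the furthest compound 1, both of them beyond the scatter. The unmeasured compound 4, `COc1ccc([C@@H]2CC(=O)c3c(O)cc(OCc4cn(CCCO)nn4)cc3O2)cc1O`, differs from compound 2 in one place: hydroxymethyl in place of hydrogen on a saturated chain carbon, two bonds along the chain from an aromatic nitrogen.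

For the measured compounds named here, only one measured step is available, and it concerns the group on the aromatic nitrogen as well: a 1.1-fold higher number from compound 1 to compound 3 (0.04 log units; within the scatter). That step, however, sits on the core of compound 1 rather than that of compound 2, and it swaps one ring-bearing group for another rather than adding a hydroxymethyl to a chain. It suggests that the group on that nitrogen is not decisive, but it is a weak guide for the present change. Compound 4 is therefore expected to stay near compound 2, with a 1.3-fold lower number from compound 2 to compound 4 (0.10 log units; within the scatter), and its estimated value is 12000 nM, within a range from 5000 nM to 30000 nM.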

Compound 4, half-maximal inhibitory concentration: 16700 nM
Estimate against measurement, compound 4: 1.4-fold (0.14 log units) below; measured number inside the range.
By their numbers in this assay, from the lowest: compounds 1 and 3 (each within the scatter of the next); then compounds 2 and 4 (each within the scatter of the next).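

In this assay, going from ethyl to 3-hydroxypropyl gives a 1.1-fold higher number from compound 2 to compound 4 (0.05 log units; within the scatter), so on the core of compound 2 this hydroxymethyl on a saturated chain carbon leaves the number within the scatter. For the compounds shown here, the only earlier step, a 1.1-fold higher number from compound 1 to compound 3 (0.04 log units; within the scatter), exchanged one ring-bearing group for another on the core of compound 1, whereas this pair gives the first reading for a change on an open chain and the first on the core of compound 2. No measurement shown bears on why the number holds at this position.

Going by these compounds, whether a longer chain, or an amine or a carboxylic acid in place of the hydroxymethyl, would move the number remains open. On these data alone, it is also open whether 3-hydroxypropyl would behave the same way on the core of compound 1.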